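This account rests on a few compounds, and the source may have more. Where it says the series, first, only, none or still open, it means among the compounds named here.

Working notes on the series. Of the compounds shown here, three have been measured in a functional assay on HeLa cells (Homo sapiens) for cytotoxicity, read by MTT assay, with a stated time of 2 days; a higher number here means that more compound is tolerated, a lower number that less compound is tolerated. Compound 1 `CC(=O)c1cc(-c2ccc(F)cc2)cc2cc(-c3ccccc3)[nH]c12` gives 38000 nM; compound 2 `COc1ccc(-c2cc(C(C)=O)c3[nH]c(-c4ccccc4)cc3c2)cc1` gives 15500 nM; compound 3 `COc1ccc(-c2cc3cc(-c4ccccc4)cc(C(C)=O)c3[nH]2)cc1` gives 18900 nM. Compound 2 holds the lowest of the three numbers, with compound 3 inside the scatter of it and compound 1 clearly higher, as the step of a 2.5-fold lower number from compound 1 to compound 2 (0.39 log units; beyond the scatter) shows.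

Compound 4 `COc1ccc(-c2cc(C(C)=O)c3[nH]c(-c4ccc(OC)cc4)cc3c2)cc1` is not yet measured. It differs from compound 2 by methoxy in place of hydrogen on an aromatic carbon, on the phenyl attached to the core; read one bond further out, phenyl becomes 4-methoxyphenyl. Going by the values given here, the only measured step that bears on this is a 2.5-fold lower number from compound 1 to compound 2 (0.39 log units; beyond the scatter), which swapped fluoro for methoxy on the other aryl ring rather than hydrogen for methoxy here, so it guides only loosely. A modest lowering in this assay or no change beyond the scatter is expected, roughly a 1.6-fold lower number from compound 2 to compound 4 (0.19 log units; within the scatter). The estimate for compound 4 is therefore 10000 nM, within 5000 nM to 25000 nM.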

Compound 4, concentration lethal to 50% of the cells: 7130 nM
Compound 4: middle estimate off by 1.4-fold (0.15 log units), on the high side; measured number inside the range.
By their numbers in this assay, from the lowest: compound 4; then compounds 2, 3 and 1 (each within the scatter of the next, the first and the last beyond it).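

Going by these compounds alone, changing phenyl to 4-methoxyphenyl gives a 2.2-fold lower number from compound 2 to compound 4 (0.34 log units; beyond the scatter) in this assay, showing that this ring, unchanged among the earlier compounds, also affects the number. The same change read from the other side gives a 2.7-fold lower number from compound 3 to compound 4 (0.42 log units; beyond the scatter), so in both pairs, adding methoxy to a compound that already carries one lowers the number beyond the scatter. Nothing available explains these steps.

On these data alone, whether an amine, a hydroxyl or a longer alkoxy chain at this place would lower the number as well remains open.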